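Aryl swap on the saturated ring carbon: compound 4

The source may hold more compounds than are shown below. What is called first, only, known or untested is meant among the compounds shown, and "the series" means these compounds.

Among the compounds with values here, compound 3 `COc1cc(C2=NN(C(C)=O)C(c3cccc(F)c3)O2)cc(OC)c1OC` gives 37.7% in a functional assay on BGC-823 cells (Homo sapiens) for antiproliferative activity, read by MTT assay, tested at 5 uM (on this read-out lower numbers stand for a weaker effect and higher numbers for a stronger effect at the one concentration tested), the highest of the three numbers measured so far; compound 2 `COc1cc(C2=NN(C(C)=O)C(c3ccccc3C(F)(F)F)O2)cc(OC)c1OC` gives 34.8%, and the two lie within the scatter of each other, while compound 1 `COc1ccc(C2OC(c3cc(OC)c(OC)c(OC)c3)=NN2C(C)=O)c(OC)c1` gives -3.1% and sits far lower. Compound 4 `COc1cc(C2=NN(C(C)=O)C(c3ccc(Cl)c([N+](=O)[O-])c3)O2)cc(OC)c1OC` differs from compound 3 in one group only: 4-chloro-3-nitrophenyl in place of 3-fluorophenyl on a saturated ring carbon. Two measured steps change the same ring. Within the data shown here, the step of a number 40.8 percentage points higher from compound 1 to compound 3 (beyond the scatter) was large, whereas the step of a number 2.9 percentage points higher from compound 2 to compound 3 (within the scatter) stayed within the scatter; no measured step shows a nitro group on this ring. A step of about a number 2.7 percentage points lower from compound 3 to compound 4 (within the scatter) is therefore expected for compound 4, none beyond the scatter. Compound 4 is estimated at 35%, with a range from 15% to 55%.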

Compound 4, a percentage reported as inhibition, at one concentration (the size of the read-out at that concentration, not a potency): 0%
Beside the measured number, compound 4's estimate is 35 percentage points above it, outside the stated range (below it).
By their numbers in this assay, from the lowest: compounds 1 and 4 (each within the scatter of the next); then compounds 2 and 3 (each within the scatter of the next).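

In this assay, a substituted phenyl other than 2,4-dimethoxyphenyl can also lose the read-out at this saturated ring carbon: 4-chloro-3-nitrophenyl gives the step of a number 37.7 percentage points lower from compound 3 to compound 4 (beyond the scatter) and the step of a number 34.8 percentage points lower from compound 2 to compound 4 (beyond the scatter). The step of a number 3.1 percentage points higher from compound 1 to compound 4 (within the scatter) puts this group with 2,4-dimethoxyphenyl, so the earlier contrast is not simply between that group and all others. No supporting data bear on the cause of this loss.

The compounds shown do not separate the chlorine from the nitro group in this drop. They also leave open how an amine in place of the nitro group would read.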